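A Cyclopropylmethyl Ester in Place of the Isobutyl Ketone

A few compounds are considered here, and "the series" means these few. Any claim that something is new, unique, unknown or untested is made for them only; others in the source may bear on it.

Three compounds have been measured in an assay on membranes from HEK293 cells for displacement of a labelled ligand from adenosine receptor A2b (Homo sapiens), read by scintillation counting, with a stated time of 30 min; a higher number here means a weaker inhibitor, a lower number a stronger inhibitor:

Compound 1 `CC1=C(C(=O)CC(C)C)C(c2ccco2)NC(=O)N1` gives 240 nM.
Compound 2 `CC1=C(C(=O)CC(C)C)C(c2ccsc2)NC(=O)N1` gives 1000 nM.
Compound 3 `CC1=C(c2ncc(C)o2)C(c2ccco2)NC(=O)N1` gives 905 nM.

Compound 1 has the lowest number of the three. The step of a 4.2-fold higher number from compound 1 to compound 2 (0.62 log units; beyond the scatter) and the step of a 3.8-fold higher number from compound 1 to compound 3 (0.58 log units; beyond the scatter) are both modest and both raise the number. Compound 4 `CC1=C(C(=O)OCC2CC2)C(c2ccco2)NC(=O)N1` differs from compound 1 by cyclopropylmethoxy in place of isobutyl on a carbonyl carbon. For the measured compounds named here, no measured step touches this carbonyl carbon in the same way; the nearest is a 3.8-fold higher number from compound 1 to compound 3 (0.58 log units; beyond the scatter), where the whole isobutylcarbonyl was exchanged, whereas compound 4 keeps the carbonyl. Compound 4 is therefore expected to move little, with the step of a 1.3-fold higher number from compound 1 to compound 4 (0.12 log units; within the scatter) estimated at most as a slight rise. Compound 4 is estimated at 320 nM, within 100 nM to 1000 nM.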

Compound 4, inhibition constant: 138 nM
Compound 4: middle estimate off by 2.3-fold (0.37 log units), on the high side; the range from low to high includes it.
By their numbers in this assay, from the lowest: compounds 4 and 1 (each within the scatter of the next); then compounds 3 and 2 (each within the scatter of the next).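

In this assay the exchange on the carbonyl carbon gives a 1.7-fold lower number from compound 1 to compound 4 (0.24 log units; within the scatter) and so cannot be told apart from the scatter. This position therefore accepts cyclopropylmethoxy, with its three-membered ring and its oxygen, as readily as isobutyl, whereas replacing the whole isobutylcarbonyl gave a 3.8-fold higher number from compound 1 to compound 3 (0.58 log units; beyond the scatter) and went beyond the scatter. Nothing measured bears on why the two groups read alike.

On these data alone, whether a methoxy, a longer chain or an amine on the same carbonyl carbon would also be accepted stays open. So does whether cyclopropylmethoxy reads the same with thiophen-3-yl in place of furan-2-yl.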